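Amide variation on a butoxy pyrazole core in rat paw edema

A few compounds are considered here, and "the series" means these few. Any claim that something is new, unique, unknown or untested is made for them only; others in the source may bear on it.

Compound 1 `COc1cc(C(=O)NC(C)C)nn1-c1ccccc1` was tested in a functional assay on the whole organism (strain Wistar) for inhibition, with Rattus norvegicus as the target, read by paw edema, with stated times of 30 min and 3 h, at a dose of 100 mg/kg by the oral route (on this read-out lower numbers stand for less inhibition and higher numbers for more inhibition at the one dose given (going by the name of the read-out)), and gave 24.8% for compound 1. Compound 2 `COc1cc(C(=O)N2CCCC2)nn1-c1ccccc1` carries one change, (pyrrolidin-1-yl in place of isopropylamino on a carbonyl carbon), and in this assay compound 2 gave 29.2%, a step of a number 4.4 percentage points higher from compound 1 to compound 2 (within the scatter). Compound 3 `CCCCOc1cc(C(=O)NC(C)C)nn1-c1ccccc1` differs from compound 1 at another point, (propyl in place of hydrogen on a saturated chain carbon bound to an oxygen on an aromatic ring), and in this assay compound 3 gave 15.8%, a step of a number 9 percentage points lower from compound 1 to compound 3 (within the scatter). Compound 4 `CCCCOc1cc(C(=O)N2CCCC2)nn1-c1ccccc1` has not yet been measured. It differs from compound 3 by pyrrolidin-1-yl in place of isopropylamino on a carbonyl carbon, and the cores of compound 3 and compound 1 differ by propyl in place of hydrogen on a saturated chain carbon bound to an oxygen on an aromatic ring. The place of this change is the same as in the move from compound 1 to compound 2, so it is the same change, seen twice among these compounds. Because the earlier step was a number 4.4 percentage points higher from compound 1 to compound 2 (within the scatter), the step from compound 3 to compound 4 is expected to be similar, a number 4.2 percentage points higher from compound 3 to compound 4 (within the scatter), in this assay. Compound 4 is therefore estimated at 20%, between 8% and 32%.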

Compound 4, a percentage reported as inhibition, in the whole organism at one dose (the size of the read-out at that dose, not a potency): 17.6%
Beside the measured number, compound 4's estimate is 2.4 percentage points above it; measured number inside the range.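

In this assay, pyrrolidin-1-yl in place of isopropylamino on a carbonyl carbon gave a number 1.8 percentage points higher from compound 3 to compound 4 (within the scatter), and the two steps of this change do not differ beyond the scatter: the same change on two cores in this assay, a number 4.4 percentage points higher (within the scatter) from compound 1 to compound 2 and a number 1.8 percentage points higher (within the scatter) from compound 3 to compound 4, 2.6 percentage points apart, within the scatter of two such steps

Propyl in place of hydrogen on the chain carbon bound to the oxygen gave a number 11.6 percentage points lower from compound 2 to compound 4 (beyond the scatter), and this change also carried from one core to the other: the same change on two cores in this assay, a number 9 percentage points lower (within the scatter) from compound 1 to compound 3 and a number 11.6 percentage points lower (beyond the scatter) from compound 2 to compound 4, 2.6 percentage points apart, within the scatter of two such steps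

Both steps of the amide change lie within the scatter, leaving no measured effect of that change on either core, and two cores do not establish that either change would carry to a further core.

The compounds shown leave open how other amines on the carbonyl, such as piperidine or morpholine, would read in this assay. They also leave open what a carboxylic acid in place of the amide, or an ethyl or longer chain on the oxygen, would give.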